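A few compounds are considered here, and "the series" means these few. Any claim that something is new, unique, unknown or untested is made for them only; others in the source may bear on it.

Measured compounds:
- compound 1 `CC(=O)c1ccccc1OC1CCN(c2ccc(-n3ccnc3)nn2)CC1` — 34 nM
- compound 2 `CC(C)(C)c1nnc(-c2ccc(N3CCC(Oc4ccccc4C(F)(F)F)CC3)nn2)o1` — 980 nM
- compound 3 `CC(C)Cc1nnc(-c2ccc(N3CCC(Oc4ccccc4C(F)(F)F)CC3)nn2)o1` — 15 nM

In an assay on microsomes from liver for inhibition of acyl-CoA desaturase 1 (Rattus norvegicus) (on this read-out lower numbers stand for stronger inhibition and higher numbers for weaker inhibition), compound 1 gives 34 nM, which places it second highest of the three numbers: compound 3 gives 15 nM and compound 2 gives 980 nM. Among the compounds with values here, the one step among the measured compounds is a 65-fold lower number from compound 2 to compound 3 (1.82 log units; beyond the scatter), which comes from a change on the other end of the shared core and does not touch the aryl ether.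

Compound 4 `Cc1ccc(OC2CCN(c3ccc(-n4ccnc4)nn3)CC2)cc1` is not yet measured. It differs from compound 1 as follows: 4-methylphenyl in place of 2-acetylphenyl on an oxygen on a saturated carbon. Within the data shown here, no measured step bears on this change directly; the measured pairs alter either the tail on the shared core or a group in place of the one on the oxygen. What can be said is that compound 1, with the 2-acetylphenyl group, gives 34 nM, and that the 4-methylphenyl group in compound 4 carries no hydrogen-bond acceptor. Among the measured compounds shown here, the expectation is a moderate weakening, as an estimated step of a 4.4-fold higher number from compound 1 to compound 4 (0.64 log units; beyond the scatter), with wide uncertainty since no comparable measured step exists. Compound 4 is estimated at 150 nM, in a range from 30 nM to 700 nM.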

Compound 4, half-maximal inhibitory concentration: 527 nM
Beside the measured number, compound 4's estimate is 3.5-fold (0.55 log units) below it; low and high end bracket the measured number.
By their numbers in this assay, from the lowest: compound 3; then compound 1; then compounds 4 and 2 (each within the scatter of the next).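

In this assay, within the data shown here, the step of a 16-fold higher number from compound 1 to compound 4 (1.19 log units; beyond the scatter) is the first measured change to the group on the oxygen, and it is large. The tail on the shared core is therefore no longer the only place where a single change moves the number this far, as it did in a 65-fold lower number from compound 2 to compound 3 (1.82 log units; beyond the scatter). Leaving with the 2-acetylphenyl group are its carbonyl double bond, its hydrogen-bond acceptor and two heavy atoms, while the acetyl gives way to a methyl at a different place on the phenyl ring, so this one step cannot separate the loss of the acetyl from the new methyl or its placement; no measurement here bears on why the number moves.

A plain phenyl on the oxygen, or a phenyl carrying a methoxy group, a nitrile or an amide, would help to show which part of the change matters. Also open, going by these compounds, is whether the 2-acetylphenyl and 4-methylphenyl groups would differ this much when paired with the isobutyl tail of compound 3.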